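Removing the Chlorines from a Growth-Inhibiting Compound

The source may hold more compounds than are shown below. What is called first, only, known or untested is meant among the compounds shown, and "the series" means these compounds.

Measured in a functional assay on DU-145 cells (Homo sapiens) for inhibition, read by trypan blue exclusion, with a stated time of 96 h; on this read-out higher numbers stand for weaker inhibition of growth and lower numbers for stronger inhibition of growth:
- compound 1 `O=C(/C(=C\c1ccc(Cl)cc1)SCc1ccc(Cl)cc1)c1ccc(Br)cc1`: 10000 nM
- compound 2 `O=C(/C(=C\c1cc(Cl)cc(Cl)c1Cl)SCc1ccc(Cl)cc1)c1ccc(Br)cc1`: 1000 nM

Of these two, compound 2 has the lower number, 1000 nM, and so the stronger inhibition of growth. Compound 3 `COc1ccccc1/C=C(/SCc1ccc(Cl)cc1)C(=O)c1ccc(Br)cc1` alters one group of compound 2: 2-methoxyphenyl in place of 2,3,5-trichlorophenyl on a double-bonded chain carbon bound to a double-bonded chain carbon. Within the data shown here, one measured step bears on this, a 10-fold lower number from compound 1 to compound 2 (1.00 log units; beyond the scatter), which came with 2,3,5-trichlorophenyl replacing 4-chlorophenyl at the same place. Among the measured compounds shown here, no measured compound carries 2-methoxyphenyl, so this is a weak guide. With 2,3,5-trichlorophenyl gone, a higher number is expected in this assay, probably a smaller rise than that step. The expected change is a 3.0-fold higher number from compound 2 to compound 3 (0.48 log units; beyond the scatter). For compound 3 the estimated value is 3000 nM, with an expected range of 800 nM to 11000 nM.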

Compound 3, concentration for 50% growth inhibition: 1000 nM
Estimate against measurement, compound 3: 3.0-fold (0.48 log units) above, within the range that was stated.
By their numbers in this assay, from the lowest: compounds 2 and 3 (each within the scatter of the next); then compound 1.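

In this assay, replacing the group at this place gave no loss (no change at the digits printed from compound 2 to compound 3 (within the scatter)), so chlorines on this ring are not needed to keep the number of compound 2. The other step (a 10-fold lower number from compound 1 to compound 3 (1.00 log units; beyond the scatter)) shows that a ring without chlorine can also beat the 4-chlorophenyl of compound 1. No measurement shown gives a reason for any of this. From the compounds shown here alone, what an amine or a carboxylic acid on this ring would do stays open, and so does whether plain phenyl would match compound 3.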